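The source may report more compounds than this note shows. Statements on the series, on what has been measured and on what is new or still open speak of the compounds shown alone.

Measured compounds in an assay on isolated protein for binding affinity to 5-hydroxytryptamine receptor 1D (Homo sapiens); a lower number here means a stronger inhibitor, a higher number a weaker inhibitor:
- Compound 1 `COc1ccc(-c2n[nH]cc2N2CCNCC2)cc1` gives > 10000 nM, a limit of the assay.
- Compound 2 `c1ccc(-c2n[nH]cc2N2CCNCC2)cc1` gives > 10000 nM, a limit of the assay.
- Compound 3 `Clc1ccccc1-c1n[nH]cc1N1CCNCC1` gives > 10000 nM, a limit of the assay.

Compound 2 stands at the limit, like the other two measured compounds; none of the three has a numerical value in this assay, so no order among them can be read. The step from compound 1 to compound 2 is a step that the two limits leave unreadable from compound 1 to compound 2, and the step from compound 2 to compound 3 is a step that the two limits leave unreadable from compound 2 to compound 3: neither is readable, since both ends sit at the limit, (the limit of > 10000 nM in this assay, at which 3 of the 3 values shown sit).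

Compound 4 `Clc1ccc(-c2n[nH]cc2N2CCNCC2)cc1` differs from compound 2 by chloro in place of hydrogen on an aromatic carbon. The two measured steps bear on this change in that a ring substituent has been varied before, yet neither gives a readable size or direction, so no step beyond the scatter can be predicted. The expected step from compound 2 to compound 4 is a step that the limit leaves unreadable from compound 2 to compound 4, that is, none that can be read. Compound 4 is expected to remain at the limit, estimated at 15000 nM with a range of 3000 nM to 60000 nM.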

Compound 4, inhibition constant: > 10000 nM
Compound 4: only a limit was reported; the forecaster's own chance of this, stated with the estimate: 85%; the middle value lies beyond the limit too.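

The steps from compound 2 and from compound 1 to compound 4 cannot be read in this assay: the limit of > 10000 nM in this assay, at which 4 of the 4 values shown sit.

The compounds shown leave open how hydrogen, methoxy and chloro on the aromatic ring rank, and whether any substituent on the shared core gives a numerical value in this assay.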